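A few compounds are considered here, and "the series" means these few. Any claim that something is new, unique, unknown or untested is made for them only; others in the source may bear on it.

Compound 1 `COc1ccc(OC)c(NC(=O)Nc2nn(-c3ccccc3)c(=O)c3ccccc23)c1` was examined in an assay on CHO cells for displacement of a labelled ligand from adenosine receptor A1 (Homo sapiens), tested at 10 uM (on this read-out higher numbers stand for more inhibition at the one concentration tested (going by the name of the read-out) and lower numbers for less inhibition), where compound 1 gives 0%. Two relatives share its core. Compound 2 `O=C(Nc1nn(-c2ccccc2)c(=O)c2ccccc12)c1ccco1` gives 23%, and compound 3 `COc1ccc(NC(=O)Nc2nn(-c3ccccc3)c(=O)c3ccccc23)c(OC)c1` gives 29%. On these three numbers compound 1 stands lowest, with both companions beyond the scatter above it. The unmeasured compound 4 `O=C(Nc1ccccc1)Nc1nn(-c2ccccc2)c(=O)c2ccccc12` differs from compound 1 by phenyl in place of 2,5-dimethoxyphenyl on an amide-type nitrogen. For the measured compounds named here, the only measured step that bears on this change is a number 29 percentage points higher from compound 1 to compound 3 (beyond the scatter), which shows that rearranging the two methoxy groups already lifts the reading modestly. Removing both methoxy groups is a different change, so that step can guide only loosely, and compound 2 shows that other variants also read above compound 1. Compound 4 is therefore expected to give 20%, within 0% to 45%. The expected step of a number 20 percentage points higher from compound 1 to compound 4 (beyond the scatter) is a modest rise.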

Compound 4, a percentage reported as inhibition, at one concentration (the size of the read-out at that concentration, not a potency): 44%
Compound 4: middle estimate off by 24 percentage points, on the low side; low and high end bracket the measured number.
By their numbers in this assay, from the lowest: compound 1; then compounds 2 and 3 (each within the scatter of the next); then compound 4.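

In this assay phenyl on the amide-type nitrogen reads above both dimethoxyphenyl groups, with a number 44 percentage points higher from compound 1 to compound 4 (beyond the scatter) and a number 15 percentage points higher from compound 3 to compound 4 (beyond the scatter) in the same direction. At this place, then, neither methoxy pattern is needed for the reading, and plain phenyl gives the highest number of the series. On the carbonyl carbon, anilino likewise reads above furan-2-yl, with a number 21 percentage points higher from compound 2 to compound 4 (beyond the scatter) as the step, and nothing measured here accounts for any of these rises. As far as these compounds go, whether phenyl carrying a single methoxy group, a chlorine or an amine would keep the reading of compound 4 stays open.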